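From methylsulfanyl to acetyl on a shared core

The source may hold more compounds than are shown below. What is called first, only, known or untested is meant among the compounds shown, and "the series" means these compounds.

Values so far in a functional assay on HaCaT cells (Homo sapiens) for antiproliferative activity, read by sulforhodamine B assay, with a stated time of 3 days; on this read-out lower numbers stand for stronger inhibition and higher numbers for weaker inhibition

Compound 1 `COC(=O)c1cc(CCc2ccccc2OC)ccc1O` - 20000 nM
Compound 2 `COC(=O)c1cc(CCc2cc(O)ccc2OC)ccc1O` - 8700 nM
Compound 3 `COC(=O)c1cc(CCc2cc(SC)ccc2OC)ccc1O` - 860 nM

Compound 3 holds the lowest number of the three, and its steps to both others lie beyond the scatter. Compound 4 `COC(=O)c1cc(CCc2cc(C(C)=O)ccc2OC)ccc1O` carries acetyl in place of methylsulfanyl on an aromatic carbon, para to a methoxy group. Among the compounds with values here, no measured step involves acetyl. At this place, hydroxy gave a 2.3-fold lower number from compound 1 to compound 2 (0.36 log units; beyond the scatter), a modest step, and methylsulfanyl gave a 23-fold lower number from compound 1 to compound 3 (1.37 log units; beyond the scatter), a large one. The swap between those two gave a 10-fold lower number from compound 2 to compound 3 (1.01 log units; beyond the scatter), also large. The size of the step thus differed with the group, so acetyl is not expected to match methylsulfanyl, and a higher number is expected in this assay. The estimated step is a 3.5-fold higher number from compound 3 to compound 4 (0.54 log units; beyond the scatter), moderate to large. For compound 4 the estimated value is 3000 nM, with an expected range from 800 nM to 11000 nM.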

Compound 4, half-maximal inhibitory concentration: 660 nM
For compound 4 the middle estimate is 4.5-fold (0.66 log units) above the measured one, and the stated range ends above it.
By their numbers in this assay, from the lowest: compounds 4 and 3 (each within the scatter of the next); then compound 2; then compound 1.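

In this assay the swap at this place gives a 1.3-fold lower number from compound 3 to compound 4 (0.11 log units; within the scatter) and so leaves acetyl and methylsulfanyl indistinguishable here. A sulfur atom is therefore not needed at this place, since acetyl also gives a 13-fold lower number from compound 2 to compound 4 (1.12 log units; beyond the scatter) and a 30-fold lower number from compound 1 to compound 4 (1.48 log units; beyond the scatter) as large steps. Nothing available explains why these two different groups give such similar numbers. From the compounds shown here alone, whether an amine, a carboxylic acid or a longer chain such as propanoyl at this place would give a similarly low number remains open.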